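The source may report more compounds than this note shows. Statements on the series, on what has been measured and on what is new or still open speak of the compounds shown alone.

Compound 1 `Cc1ccc(-c2nn(-c3ccccc3)cc2-c2nc3ccccc3[nH]2)cc1` gives 4950 nM
Compound 2 `COc1ccc(S(=O)(=O)n2c(-c3cn(-c4ccccc4)nc3-c3ccc(F)cc3)nc3ccccc32)cc1` gives 390 nM
Compound 3 `COc1ccc(S(=O)(=O)n2c(-c3cn(-c4ccccc4)nc3-c3ccc(C(F)(F)F)cc3)nc3ccccc32)cc1` gives 250 nM

These numbers all come from a functional assay on HeLa cells (Homo sapiens) for antiproliferative activity, read by MTT assay, with a stated time of 24 h; a lower number here means a stronger inhibitor, a higher number a weaker inhibitor. Compound 3 lies within the scatter of compound 2, and both sit far under compound 1. Compound 4 `O=S(=O)(c1ccc(Cl)cc1)n1c(-c2cn(-c3ccccc3)nc2-c2ccc(C(F)(F)F)cc2)nc2ccccc21` differs from compound 3 in one place: chloro in place of methoxy on an aromatic carbon, para to a large group (chloro in place of methoxy on an aromatic carbon). Going by the values given here, the only measured step, a 1.6-fold lower number from compound 2 to compound 3 (0.19 log units; within the scatter), swapped a different group and stayed within the scatter. Among the compounds with values here, no measured step touches the methoxy, so the data give no direction. In this assay no shift beyond the scatter is expected. The expected step is a 1.1-fold higher number from compound 3 to compound 4 (0.03 log units; within the scatter). Compound 4 is estimated at 270 nM, with an expected range of 100 nM to 700 nM.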

Compound 4, half-maximal inhibitory concentration: 3060 nM
For compound 4 the middle estimate is 11-fold (1.05 log units) below the measured one, and the stated range ends below it.
By their numbers in this assay, from the lowest: compounds 3 and 2 (each within the scatter of the next); then compounds 4 and 1 (each within the scatter of the next).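

Changing (4-methoxyphenyl)sulfonyl to (4-chlorophenyl)sulfonyl in this assay gives a 12-fold higher number from compound 3 to compound 4 (1.09 log units; beyond the scatter) and so shows that this position responds strongly to a single small swap. Going by these compounds alone, the only earlier step, a 1.6-fold lower number from compound 2 to compound 3 (0.19 log units; within the scatter) at another place, stayed within the scatter, so this is the first sign that methoxy here outperforms chloro. No measurement shown explains why this swap matters so much.

Going by these compounds, it remains open whether any replacement of methoxy would cost as much as chloro does. On these data alone, how an amine, a hydroxyl or a longer ethoxy chain would behave at this place also remains unknown.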